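Swapping 3-hydroxyphenyl for 4-chlorophenyl on compound 3

A few compounds are considered here, and "the series" means these few. Any claim that something is new, unique, unknown or untested is made for them only; others in the source may bear on it.

In a physicochemical assay for lipophilicity, measured as octanol-water partition (a lower number here means a more polar compound, a higher number a more lipophilic compound), compound 3 `CC1=C(C(=O)OCc2cccnc2)C(c2cccc(O)c2)C2=C(CCCC2=O)N1` gives 1.21, the lowest of three numbers, against 1.58 for compound 1 `CC1=C(C(=O)OCc2ccccn2)C(c2cccc(O)c2)C2=C(CCCC2=O)N1` and 2.6 for compound 2 `CCCC1C(C(=O)OCc2ccccn2)=C(C)NC2=C1C(=O)CCC2`. Compound 4 `CC1=C(C(=O)OCc2cccnc2)C(c2ccc(Cl)cc2)C2=C(CCCC2=O)N1` carries 4-chlorophenyl in place of 3-hydroxyphenyl on a saturated ring carbon. The most relevant measured step replaces the same group, though with propyl: a number 1.02 log units higher from compound 1 to compound 2 (beyond the scatter), a large step beyond the scatter. The modest step of a number 0.37 log units lower from compound 1 to compound 3 (beyond the scatter) involves only the pyridinyl swap, elsewhere in the structure, so it bears little on this change. A large upward step is therefore expected, similar in size to the propyl one. That expected step is a number 1.29 log units higher from compound 3 to compound 4 (beyond the scatter). The estimate for compound 4 is 2.5, within an expected range of 2 to 3.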

Compound 4, partition coefficient: 1.87
Compound 4: the middle estimate sits 0.63 log units above what was measured; the measured number lies below the stated range.
By their numbers in this assay, from the lowest: compound 3; then compounds 1 and 4 (each within the scatter of the next); then compound 2.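

In this assay, keeping an aromatic ring of carbon only on this saturated ring carbon, with 4-chlorophenyl in place of 3-hydroxyphenyl, gives a number 0.66 log units higher from compound 3 to compound 4 (beyond the scatter). Propyl in place of the same group gave a number 1.02 log units higher from compound 1 to compound 2 (beyond the scatter), so the replacing group matters at this carbon, not only the departure of 3-hydroxyphenyl, though those two steps start from different pyridinyl isomers. As far as these compounds go, whether 3-chlorophenyl, an aminophenyl or a carboxylic acid on the ring would behave alike remains open, as does the same swap with pyridin-2-yl in place of pyridin-3-yl. Nothing available here explains the size of either step.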